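The source may hold more compounds than are shown below. What is called first, only, known or untested is meant among the compounds shown, and "the series" means these compounds.

Measured compounds:
- compound 1, `COc1ccc(-c2nnc(SCC(=O)c3ccccc3)n2-c2ccccc2)cc1OC`: 56%
- compound 2, `O/N=C(/CSc1nnc(-c2ccccc2)n1-c1ccccc1)c1ccccc1`: 60%

Both compounds were tested in a functional assay on the whole organism (strain albino) for inhibition, with Rattus norvegicus as the target, read by paw edema, with a stated time of 1 h, at a dose of 0.28 mmol/kg by the oral route; a higher number here means more inhibition at the dose given (going by the name of the read-out), a lower number less inhibition. Compound 1 gives 56%, and compound 2 gives 60%. Of the two numbers that of compound 2 is the higher, but the two values lie within the scatter of each other, so the measurements do not separate the two compounds.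

The next compound, compound 3, `COc1ccc(-c2nnc(SC/C(=N/O)c3ccccc3)n2-c2ccccc2)cc1OC`, has not yet been measured in this assay. Compared with compound 2 it differs in one place: 3,4-dimethoxyphenyl in place of phenyl on an aromatic carbon. Within the data shown here, no measured pair shows a change of this kind on its own, so its effect is not known from the data. Among the measured compounds shown here, the only guide is that compound 1, which carries the 3,4-dimethoxyphenyl group, and compound 2, which carries the phenyl group, gave values within the scatter of each other, though they also differ elsewhere. On that basis no step beyond the scatter is expected, and the step of a number 2 percentage points lower from compound 2 to compound 3 (within the scatter) is an estimate only. Compound 3 is thus expected to give about 58%, somewhere between 45% and 70%.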

Compound 3, a percentage reported as inhibition, in the whole organism at one dose (the size of the read-out at that dose, not a potency): 55%
Compound 3: middle estimate off by 3 percentage points, on the high side; low and high end bracket the measured number.
By their numbers in this assay, from the lowest: compounds 3, 1 and 2 (each within the scatter of the next).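

In this assay, among these compounds, 3,4-dimethoxyphenyl in place of phenyl on the aromatic carbon of the five-membered ring now stands as the only change between two compounds, and it gives a number 5 percentage points lower from compound 2 to compound 3 (within the scatter), so this larger group, with its 2 hydrogen-bond acceptors, does not separate the pair at this dose. The same compound also isolates a second change, on the saturated chain carbon bound to a sulfur, where the oxime replaces the ketone carbonyl and gives a number 1 percentage points lower from compound 1 to compound 3 (within the scatter), so that swap does not separate its pair either. Nothing available explains why either change leaves the read-out within the scatter.

Going by these compounds, with only these two swaps, each tested on a single background, it remains open whether any group at the aromatic carbon can shift the inhibition beyond the scatter, for example an amine, a carboxylic acid or a single methoxy on the phenyl ring. On these data alone, since every number comes from one dose and one time, it also remains open whether the compounds would still look alike at a lower dose or a later time.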